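The source may hold more compounds than are shown below. What is called first, only, known or untested is meant among the compounds shown, and "the series" means these compounds.

In a functional assay on HCT-15 cells (Homo sapiens) for cytotoxicity, read by colorimetric assay and MTT assay (on this read-out lower numbers stand for stronger inhibition and higher numbers for weaker inhibition), compound 1 (`COc1cccc2cc(-c3ccccc3)c(O)nc12`) gives 10000 nM and compound 2 (`COc1cc(OC)c2cc(-c3ccc(OCc4ccccc4)cc3)c(O)nc2c1`) gives 10000 nM on the same read-out. Compound 3 (`CCOC(=O)Cn1c(=O)c(-c2ccc(OC)cc2)cc2c(OC)cc(OC)cc21`) gives 10000 nM in this company, level with both at the digits reported and within the scatter of each. Compound 4 (`COc1ccc(-c2cc3c(OC)cc(OC)cc3n(CC#N)c2=O)cc1`) departs from compound 3 at a single place, a saturated chain carbon bound to an aromatic nitrogen, where cyano stands in place of ethoxycarbonyl (cyano in place of ethoxycarbonyl on a saturated chain carbon bound to an aromatic nitrogen). Cut one bond further out, the same difference reads (ethoxycarbonyl)methyl to cyanomethyl. Within the data shown here, no two measured compounds differ in one place only, so the data give no direct measure of what such a change does. All they offer is a flat picture, with compound 3 at 10000 nM and nothing yet separating the three measured compounds. On that basis no step beyond the scatter is expected in this assay, in either direction. The estimated change (no change at the digits printed from compound 3 to compound 4 (within the scatter)) is accordingly expected to stay small. The estimate for compound 4 is 10000 nM with an expected range from 4000 nM to 15000 nM for repeated measurements.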

Compound 4, half-maximal inhibitory concentration: 10000 nM
For compound 4 middle estimate and measured number coincide at the digits printed; low and high end bracket the measured number.
By their numbers in this assay, from the lowest: compounds 1, 2, 3 and 4 (each within the scatter of the next).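

In this assay, among these compounds, the exchange on a saturated chain carbon bound to an aromatic nitrogen gives the first reading of a change at one place in these compounds, and it amounts to no change at the digits printed from compound 3 to compound 4 (within the scatter) in this series. At this place, then, ethoxycarbonyl with its 5 heavy atoms and cyano with its 2 cannot be told apart on this read-out, and the double bond of the one and the triple bond of the other leave no mark that this assay separates from the scatter. No measurement at hand says why the two compounds read alike.

This single pair does not show whether other groups on the same chain carbon, such as a carboxylic acid, a primary amine or a longer alkyl chain, would also read level with compound 3 in this assay. It also leaves open whether the same exchange would read the same way with another group in place of the methoxy groups on the shared core, since one pair speaks only for the core of compound 3 and compound 4.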